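This account rests on a few compounds, and the source may have more. Where it says the series, first, only, none or still open, it means among the compounds named here.

Measured compounds:
- compound 2 `Oc1ccc(-c2cc(-c3ccccc3)nc(-c3ccccc3Cl)c2)cc1`, a functional assay on HCT-15 cells (Homo sapiens) for cytotoxicity, read by CCK-8 assay and cell counting, with a stated time of 2 days; a lower number here means a stronger inhibitor, a higher number a weaker inhibitor: 4990 nM
- compound 3 `Oc1ccc(-c2cc(-c3ccco3)nc(-c3ccccc3Cl)c2)cc1`, this assay: 5460 nM
- compound 1 `Oc1ccc(-c2cc(-c3ccccn3)nc(-c3ccccc3Cl)c2)cc1`, this assay: "not determined" (no result reported)

Compound 3 has the highest of the two numbers reported in this assay; its nearest neighbour is compound 2, with a 1.1-fold higher number from compound 2 to compound 3 (0.04 log units; within the scatter), so the two cannot be separated. Compound 1 gives no number in this assay and carries nothing further.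

Compound 4 `Oc1ccc(-c2cc(-c3ccsc3)nc(-c3ccccc3Cl)c2)cc1` differs from compound 3 in one place: thiophen-3-yl in place of furan-2-yl on an aromatic carbon. Among the measured compounds shown here, the only measured step at this position, from phenyl to furan-2-yl, is the one from compound 2 to compound 3 and stays within the scatter. A second swap of one five-membered aromatic ring with a single hetero atom for another is therefore not expected to move the number beyond the scatter in this assay, in either direction. Compound 4 is thus expected near compound 3, with a 1.1-fold lower number from compound 3 to compound 4 (0.02 log units; within the scatter), giving an estimated 5200 nM with a range of 2000 nM to 13000 nM.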

Compound 4, half-maximal inhibitory concentration: 5830 nM
Compound 4: the middle estimate sits 1.1-fold (0.05 log units) below what was measured; the range from low to high includes it.
By their numbers in this assay, from the lowest: compounds 2, 3 and 4 (each within the scatter of the next).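

In this assay, thiophen-3-yl on this aromatic carbon, next to the ring nitrogen, stays level with furan-2-yl, a 1.1-fold higher number from compound 3 to compound 4 (0.03 log units; within the scatter), and with phenyl, a 1.2-fold higher number from compound 2 to compound 4 (0.07 log units; within the scatter). The position now has three aromatic rings that cannot be separated, and the five-membered exchange replaces oxygen with sulfur and changes the point of attachment without a step beyond the scatter. No evidence on the cause of this flat result is at hand.

Going by these compounds, it remains open whether a group of another kind on this carbon, such as an amine, a carboxylic acid or a longer alkyl chain, would move the number beyond the scatter. On these data alone, the contribution of the 2-chlorophenyl and 4-hydroxyphenyl groups also stays open, as compounds 2, 3 and 4 all carry both unchanged.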